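This account rests on a few compounds, and the source may have more. Where it says the series, first, only, none or still open, it means among the compounds named here.

Of the compounds shown here, two from this series have been measured in an assay on CHO cells for antagonist activity at transient receptor potential cation channel subfamily V member 1 (Homo sapiens), read by FLIPR; a lower number here means a stronger inhibitor, a higher number a weaker inhibitor. Compound 1 `CC(C(=O)NCc1ccc(C(F)(F)F)cc1N1CCCCCCC1)c1ccc(NS(C)(=O)=O)c(F)c1` gives 2.8 nM, while compound 2 `CC(C(=O)NCc1ccc(C(F)(F)F)cc1N1CCN(C2CCCCC2)CC1)c1ccc(NS(C)(=O)=O)c(F)c1` gives 13.8 nM. Among the compounds with values here, compound 2 therefore stands with the highest of the two numbers, and the only step available, a 4.9-fold higher number from compound 1 to compound 2 (0.69 log units; beyond the scatter), describes how the larger cyclic group weakened inhibition.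

Compound 3 `CCCOc1cc(C(F)(F)F)ccc1CNC(=O)C(C)c1ccc(NS(C)(=O)=O)c(F)c1` is not yet measured. Compared with compound 2, the change is propoxy in place of 4-cyclohexylpiperazin-1-yl on an aromatic carbon, so a small chain replaces a bulky two-ring group at the same position on the shared core.

Within the data shown here, no measured step covers a propoxy group, so the expectation rests only on the observation that the smaller group in compound 1 gave the lower number in this assay. Since propoxy is smaller again, compound 3 is estimated to come in somewhat stronger than compound 2, with the step of a 2.8-fold lower number from compound 2 to compound 3 (0.44 log units; beyond the scatter) expected. Compound 3 is therefore expected to give about 5 nM in this assay, plausibly anywhere between 1.5 nM and 20 nM.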

Compound 3, inhibition constant: 2 nM
For compound 3 the middle estimate is 2.5-fold (0.40 log units) above the measured one, and the stated range covers the measured number.
By their numbers in this assay, from the lowest: compounds 3 and 1 (each within the scatter of the next); then compound 2.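

In this assay, putting propoxy in place of 4-cyclohexylpiperazin-1-yl gives a 6.9-fold lower number from compound 2 to compound 3 (0.84 log units; beyond the scatter) at this aromatic carbon, ortho to a large group and meta to a trifluoromethyl group, so this position does not need a ring to reach the low numbers seen here: a small open chain joined through oxygen serves as well. Set against the eight-membered ring of compound 1, the same chain gives a 1.4-fold lower number from compound 1 to compound 3 (0.15 log units; within the scatter) and so cannot be told apart from that ring in this assay, which means that two quite different groups, one with a ring and one without, sit at the same level while only the two-ring group of compound 2 stands apart. No measurement on hand explains why these groups behave as they do.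

The compounds shown leave open how much the chain length matters, as a shorter ethoxy or a longer butoxy group would test, and whether the oxygen matters, as a propylamino group would test. They also leave open which part of 4-cyclohexylpiperazin-1-yl goes with the weaker number, a question that a piperazine ring carrying only a methyl group could help to settle.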